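A Hydroxy Group in Place of an Amide on the Saturated Ring

This account rests on a few compounds, and the source may have more. Where it says the series, first, only, none or still open, it means among the compounds named here.

Of the compounds shown here, three sharing one core have been measured in a functional assay on CHO-K1 cells for antagonist activity at melanin-concentrating hormone receptor 1 (Homo sapiens), read by inositol phosphate accumulation; a higher number here means a weaker inhibitor, a lower number a stronger inhibitor. Compound 1 `Cc1nc(N2CCN(C3CCOCC3)CC2)nc2ccc(NC(=O)COc3ccc(Cl)cc3)cc12` gives 115 nM. Compound 2 `Cc1nc(N2CCC(NC(=O)C(C)C)CC2)nc2ccc(NC(=O)COc3ccc(Cl)cc3)cc12` gives 54 nM, the lowest of the three numbers; its nearest neighbour is compound 1, which stands beyond the scatter above it. Going by the values given here, compound 3 `Cc1nc(N2CCC(N3CCCC3)CC2)nc2ccc(NC(=O)C(C)Oc3ccc(Cl)cc3)cc12` gives 401 nM, the highest of the three; it differs from the others in more than one place, so no single step can be drawn to it.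

Compound 4 `Cc1nc(N2CCC(O)CC2)nc2ccc(NC(=O)COc3ccc(Cl)cc3)cc12` has not yet been measured. It differs from compound 2 in one place: hydroxy in place of (isopropylcarbonyl)amino on a saturated ring carbon. Among the compounds with values here, no pair of measured compounds shows this change, so its size can only be estimated. Among the measured compounds, the one carrying the (isopropylcarbonyl)amino group on the saturated ring, compound 2, stands lowest at 54 nM, while compound 1, with a different group on that ring, stands higher at 115 nM. On that basis a step upward, beyond the scatter, is expected from compound 2 to compound 4, namely a 3.7-fold higher number from compound 2 to compound 4 (0.57 log units; beyond the scatter). Compound 4 is therefore estimated to give 200 nM in this assay, within an expected range from 60 nM to 700 nM.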

Compound 4, half-maximal inhibitory concentration: 163 nM
Compound 4: the middle estimate sits 1.2-fold (0.09 log units) above what was measured; measured number inside the range.
By their numbers in this assay, from the lowest: compound 2; then compounds 1 and 4 (each within the scatter of the next); then compound 3.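

In this assay, going by these compounds alone, the change gives the first step that can be read at this saturated ring carbon, a 3.0-fold higher number from compound 2 to compound 4 (0.48 log units; beyond the scatter), which is modest but beyond the scatter. The (isopropylcarbonyl)amino group has six heavy atoms and the hydroxy has one, so compound 4 shows that this much of the substituent can be given up at the cost of that step, while the count of one hydrogen-bond donor and one hydrogen-bond acceptor is the same on both sides. Nothing available explains why the number rises from compound 2 to compound 4.

Within the data shown here, the single step also cannot separate the parts of the group that leaves, so it remains open whether a plain amino group, which keeps the nitrogen, or an acetylamino group, which keeps the carbonyl with a shorter chain, would stand closer to compound 2 or to compound 4. Going by these compounds, it is equally open how a methoxy group, which keeps the oxygen but not its hydrogen, or a longer acyl chain such as pivaloylamino would read at this ring carbon.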